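Removing a carbonyl from a side chain on the shared core

The source may report more compounds than this note shows. Statements on the series, on what has been measured and on what is new or still open speak of the compounds shown alone.

Three compounds share the core of compound 1 `C#CCOc1ccc2c(=O)c(-c3cc(OC)c(OC)cc3OC)coc2c1` and differ only in the group on a saturated chain carbon bound to an oxygen on an aromatic ring. In a functional assay on U-251 cells (Homo sapiens) for antiproliferative activity, read by MTT assay, with a stated time of 24 h (a higher number here means a weaker inhibitor, a lower number a stronger inhibitor), compound 1 gives 6450 nM. Compound 2 `COc1cc(OC)c(-c2coc3cc(OCc4ccccc4)ccc3c2=O)cc1OC` gives 6750 nM in this assay, and the step of a 1.0-fold higher number from compound 1 to compound 2 (0.02 log units; within the scatter) is within the scatter. Compound 3 `COc1cc(OC)c(-c2coc3cc(OCC(=O)c4cccc(C(F)(F)F)c4)ccc3c2=O)cc1OC` reaches only a limit of this assay, > 10000 nM, so no number is known for it; it sits at the limit of > 10000 nM in this assay, at which 1 of the 3 values shown sits.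

Compound 4 `COc1cc(OC)c(-c2coc3cc(OCc4ccccc4C(F)(F)F)ccc3c2=O)cc1OC` is not yet measured. It differs from compound 3 by 2-(trifluoromethyl)phenyl in place of (3-(trifluoromethyl)phenyl)carbonyl on a saturated chain carbon bound to an oxygen on an aromatic ring. Among the compounds with values here, the steps that bear on this are an at least 1.5-fold higher number from compound 1 to compound 3 (0.19 log units; that floor lies within the scatter) and an at least 1.4-fold higher number from compound 2 to compound 3 (0.17 log units; that floor lies within the scatter), both floors lying within the scatter. Compound 4 resembles compound 2 in carrying a phenyl on that chain carbon, so the estimate leans on 6750 nM of compound 2. The expected step of an at least 1.4-fold lower number from compound 3 to compound 4 (0.15 log units; that floor lies within the scatter) is a return toward a measurable number, and compound 4 is estimated at 7000 nM, within a range from 3000 nM to 20000 nM.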

Compound 4, half-maximal inhibitory concentration: > 10000 nM
Compound 4 was reported as a limit; the forecaster's own chance of this, stated with the estimate: 30%; middle value at least 1.4-fold (0.15 log units) away from the limit.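

With the carbonyl gone, compound 4 still sits at a limit of this assay, so the carbonyl of compound 3 is not needed for a compound in this set to reach that limit: the limit of > 10000 nM in this assay, at which 2 of the 4 values shown sit.

Placing trifluoromethyl on the phenyl of compound 2 gives an at least 1.4-fold higher number from compound 2 to compound 4 (0.17 log units; that floor lies within the scatter), and exchanging the ethynyl of compound 1 for 2-(trifluoromethyl)phenyl gives an at least 1.5-fold higher number from compound 1 to compound 4 (0.19 log units; that floor lies within the scatter), so each step is known only as a floor. The step between the two limits, from compound 3 to compound 4, cannot be read.

Going by these compounds, the actual values of compound 3 and compound 4 remain unknown, so these compounds cannot be ranked against each other. Also open, on these data alone, is whether a fluorine or a nitrile on that phenyl, or an amine or a carboxylic acid on the saturated chain carbon, would give a measurable number in this assay.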